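From acetyl to benzoyl on a shared anilide core

The compounds below may be only part of what the source reports. "The series", "measured", "known", "first", "only" and "open" are said of these compounds alone.

Measured so far:
compound 1, `COc1ccc(C(=O)Nc2ccccc2)cc1NC(=O)C(C)Cl`: 200 uM
compound 2, `COc1ccc(C(=O)Nc2ccccc2)cc1NC(C)=O`: > 703 uM

In an ADME assay on MDCK cells (Canis lupus familiaris) for cytotoxicity, read by cytopathic effect, with a stated time of 48 h (a higher number here means that more compound is tolerated, a lower number that less compound is tolerated), compound 2 sits at a limit of the measurement, > 703 uM. Among the compounds with values here, the one measured step, an at least 3.5-fold higher number from compound 1 to compound 2 (0.54 log units; beyond the scatter), carried the number up to that limit, as the limit of > 703 uM in this assay, at which 1 of the 2 values shown sits, shows. Compound 3, `COc1ccc(C(=O)Nc2ccccc2)cc1NC(=O)c1ccccc1`, differs from compound 2 by phenyl in place of methyl on a carbonyl carbon. Within the data shown here, no measured step exchanges methyl for phenyl at this position, so the step of an at least 3.5-fold higher number from compound 1 to compound 2 (0.54 log units; beyond the scatter) bears on it only loosely. Compound 3 is therefore expected to remain near the limit, with a step of an at least 2.0-fold lower number from compound 2 to compound 3 (0.30 log units; that floor lies within the scatter) in this assay. The estimate for compound 3 is 350 uM, within a range of 100 uM to 703 uM.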

Compound 3, half-maximal toxic concentration: 193 uM
For compound 3 the middle estimate is 1.8-fold (0.26 log units) above the measured one, within the range that was stated.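

In this assay, phenyl in place of methyl on a carbonyl carbon gives an at least 3.6-fold lower number from compound 2 to compound 3 (0.56 log units; beyond the scatter), so a second group besides 1-chloroethyl now stands well under the acetyl compound. Phenyl and 1-chloroethyl cannot be told apart at this position, with a 1.0-fold lower number from compound 1 to compound 3 (0.02 log units; within the scatter). Compound 2 stands at a limit, so the step from it is only a floor: the limit of > 703 uM in this assay, at which 1 of the 3 values shown sits.

The compounds shown leave open how a longer alkyl chain, or a phenyl ring carrying an amine or a carboxylic acid, would behave on this carbonyl carbon.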